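A few compounds are considered here, and "the series" means these few. Any claim that something is new, unique, unknown or untested is made for them only; others in the source may bear on it.

Measured compounds, binding affinity:
compound 1 `Cn1ncc2cc(-c3cnc4[nH]cnc4c3N3CCC4(CCNC4=O)CC3)ccc21`: 5 nM
compound 2 `Cn1ncc2cc(-c3cnc4sccc4c3N3CCC4(CCNC4=O)CC3)ccc21`: "not determined" (no result reported)
compound 3 `O=C1NCCC12CCN(c1c(-c3ccc4scnc4c3)cnc3[nH]ccc13)CC2`: 14 nM

In an assay on cells for binding affinity to Cyclin-C/Cyclin-dependent kinase 19 (Homo sapiens), read by LanthaScreen (a lower number here means a stronger inhibitor, a higher number a weaker inhibitor), compound 1 gives 5 nM. Compound 2 stands in this assay as "not determined" (no result reported). Compound 3 gives 14 nM in this assay, the higher of the two numbers; the gap to compound 1 is beyond the scatter, so compound 3 is the weaker inhibitor of the pair. Within the data shown here, no pair of measured compounds differs in a single place, so no measured step can be drawn on.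

Compound 4 `O=C1NCCC12CCN(c1c(-c3ccc4[nH]cnc4c3)cnc3[nH]ccc13)CC2` is to be measured in this assay. The change from compound 3 is 1H-benzimidazol-5-yl in place of 1,3-benzothiazol-5-yl on an aromatic carbon. The two measured numbers sit in a narrow band, with compound 1 at 5 nM and compound 3 at 14 nM, so for compound 4 a small step toward a lower number is expected, not clearly beyond the scatter. The step expected from this change is a 1.4-fold lower number from compound 3 to compound 4 (0.15 log units; within the scatter). For compound 4 the estimated value in this assay is 10 nM, within a range from 4 nM to 30 nM.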

Compound 4, half-maximal inhibitory concentration: 17 nM
Compound 4: the middle estimate sits 1.7-fold (0.23 log units) below what was measured; measured number inside the range.
By their numbers in this assay, from the lowest: compound 1; then compounds 3 and 4 (each within the scatter of the next).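

In this assay, among these compounds, the only single-place step reads a 1.2-fold higher number from compound 3 to compound 4 (0.08 log units; within the scatter), within the scatter, where 1,3-benzothiazol-5-yl leaves and 1H-benzimidazol-5-yl enters. At this aromatic carbon, ortho to a large group and two atoms from the ring nitrogen, the assay therefore does not separate the two groups, even though the entering group has nitrogen where the leaving group has sulfur and carries a hydrogen-bond donor the other lacks. No measured evidence on the compounds offers a reason for this near-identity.

As far as these compounds go, whether a single six-membered ring such as plain phenyl, or one bearing a carboxylic acid or an aminomethyl group, would hold up at this carbon remains open. Also open, from the compounds shown here alone, is whether the same exchange would read alike on the core of compound 1.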